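The source may report more compounds than this note shows. Statements on the series, on what has been measured and on what is new or still open speak of the compounds shown alone.

Compound 1 `COc1cc(Cl)cc(-c2nn(-c3cccc(NC(=O)Nc4ccc(Cl)c(C(F)(F)F)c4)c3)cc2-c2ccncc2)c1` was tested in a functional assay on U-251 cells (Homo sapiens) for inhibition, read by sulforhodamine B assay, with a stated time of 48 h, tested at 0.01 uM (a lower number here means a stronger effect, a higher number a weaker effect of the compound at the concentration tested), where compound 1 gives 98%. Going by the values given here, only one other compound has a number there: compound 2 `COc1cc(Cl)cc(-c2nn(-c3cccc(NC(=O)Nc4cc(C(F)(F)F)cc(C(F)(F)F)c4)c3)cc2-c2ccncc2)c1`, which in this assay gives 96%. Compound 1 stands at the top of these two numbers, but compound 2 sits so close that the two cannot be told apart within the usual scatter; both sit near the upper end of the scale, meaning that at this concentration neither produces a strong effect.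

Compound 3 `COc1cc(Cl)cc(-c2nn(-c3cccc(NC(=O)c4cccc(C(F)(F)F)c4)c3)cc2-c2ccncc2)c1` has not been measured. It differs from compound 1 in one place: 3-(trifluoromethyl)phenyl in place of (4-chloro-3-(trifluoromethyl)phenyl)amino on a carbonyl carbon. The urea of compound 1 thus becomes an amide in compound 3.

Among the compounds with values here, with no measured step of this kind to lean on, and with both known numbers lying close together near the top of the scale, the step from compound 1 to compound 3 is expected to be small, a number 1 percentage points lower from compound 1 to compound 3 (within the scatter), with no clear direction beyond the scatter. Compound 3 is therefore estimated to give 97% in this assay, within a range from 87% to 104%.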

Compound 3, a percentage reported as activity, at one concentration (the size of the read-out at that concentration, not a potency): 94%
For compound 3 the middle estimate is 3 percentage points above the measured one; low and high end bracket the measured number.
By their numbers in this assay, from the lowest: compounds 3, 2 and 1 (each within the scatter of the next).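

In this assay, placing 3-(trifluoromethyl)phenyl in place of (4-chloro-3-(trifluoromethyl)phenyl)amino on the carbonyl carbon gives a number 4 percentage points lower from compound 1 to compound 3 (within the scatter). This shows that the urea can become an amide, losing its hydrogen-bond donor and the ring chlorine, without moving the read-out beyond the scatter, although all the compounds shown remain near the weak end of the scale at this concentration. Nothing measured explains why this change leaves the read-out in place.

Because the step changes the linker and removes the chlorine together, the compounds shown leave open what each change does alone, which an amide carrying 4-chloro-3-(trifluoromethyl)phenyl could separate. They also leave open whether a clearly stronger effect is possible with a different group on the carbonyl carbon, such as a morpholine amine or a longer alkyl chain.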